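Swapping a chain-end thiol for a hydroxyl on a weak cytotoxic scaffold

The source may report more compounds than this note shows. Statements on the series, on what has been measured and on what is new or still open speak of the compounds shown alone.

The measured compounds, each in a functional assay on U-87MG ATCC cells (Homo sapiens) for cytotoxicity, read by MTT assay, with a stated time of 24 h; a lower number here means a stronger inhibitor, a higher number a weaker inhibitor:
compound 1 `COc1ccccc1C(=O)Nc1cn(-c2ccccc2)nc1-c1ccccc1` gives 81000 nM;
compound 2 `O=C(CCCCCCCCCCS)Nc1cn(-c2ccccc2)nc1-c1ccccc1` gives 90000 nM;
compound 3 `NCCCCCCCCCCCC(=O)Nc1cn(-c2ccccc2)nc1-c1ccccc1` gives 77000 nM.

All three share one core and differ only in the group attached through the amide. Compound 2 has the highest of the three numbers, yet its neighbours sit within the scatter: compound 1 is a hair lower and compound 3 a little lower still, so none of the three can be told apart with confidence.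

Compound 4 `O=C(CCCCCCCCCCO)Nc1cn(-c2ccccc2)nc1-c1ccccc1` is not yet measured. It differs from compound 2 by hydroxy in place of sulfanyl on a saturated chain carbon, ten or more bonds along the chain from a carbonyl carbon. Among the compounds with values here, the one step in hand that speaks to this place is a 1.2-fold lower number from compound 2 to compound 3 (0.07 log units; within the scatter), where a different small group replaced the same sulfanyl at the same chain end and the number barely moved. Within the data shown here, with that as the only guide, the step from compound 2 to compound 4 is expected to be a 1.1-fold lower number from compound 2 to compound 4 (0.02 log units; within the scatter), no change beyond the scatter in this assay. Compound 4 is therefore estimated at 85000 nM, within a range of 45000 nM to 170000 nM.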

Compound 4, half-maximal inhibitory concentration: > 150000 nM
Compound 4: no number, only a limit; the forecaster's own chance of this, stated with the estimate: 20%; at least 1.7-fold (0.24 log units) between middle value and limit.
By their numbers in this assay, from the lowest: compounds 3, 1 and 2 (each within the scatter of the next). At a limit, above all of these: compound 4.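

In this assay compound 4 gives a limit of the assay and not a number: the limit of > 150000 nM in this assay, at which 1 of the 4 values shown sits. Within the data shown here, this is the first change at this chain end whose reading is open on the upper side, even though hydroxy and sulfanyl are each a single heavy atom with the same hydrogen-bond counts; the floors read an at least 1.6-fold higher number from compound 2 to compound 4 (0.22 log units; that floor lies within the scatter) and an at least 1.9-fold higher number from compound 3 to compound 4 (0.28 log units; that floor lies within the scatter). Going by these compounds, both are only floors and lie within the scatter, so the true size of either step is unknown, and compound 4 cannot yet be said to differ from the other compounds.

The compounds shown leave open how a carboxylic acid or a methoxy group would read at the same chain end. They also leave open whether a hydroxy on a shorter chain would reach the same limit.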